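The source may hold more compounds than are shown below. What is called first, only, known or untested is meant among the compounds shown, and "the series" means these compounds.

Working notes on the series.

Three compounds have numbers in an assay on isolated protein for inhibition of AP2-associated protein kinase 1 (Homo sapiens), with a stated time of 3 h, in the presence of a further agent that is not named here; a higher number here means a weaker inhibitor, a lower number a stronger inhibitor. Compound 1 `COC(=O)Nc1cc(-c2cnc(OC[C@@](C)(N)CC(C)C)c(Cl)c2)ccn1` gives 0.4 nM in this assay. Compound 3 `CC(=O)Nc1cc(-c2cc(F)c(OC[C@@H](N)CC(C)C)cc2F)ccn1` gives 1.3 nM in this assay. Compound 2 `CC(C)C[C@H](N)COc1ccc(-c2ccnc(NCc3ccccc3)c2)cc1` gives 127 nM in this assay, the highest of the three numbers shown; its nearest neighbour is compound 3, with a number well below it, and the gap to compound 1 is wider still, both beyond the usual scatter.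

Compound 4 `CC(=O)Nc1cc(-c2ccc(OC[C@@H](N)CC(C)C)cc2)ccn1` has not yet been measured in this assay. It differs from compound 2 in one place: acetyl in place of benzyl on a nitrogen on an aromatic ring. The rest of the molecule, the aminoalkyl ether chain and the shared core, is unchanged between compound 2 and compound 4.

Among the compounds with values here, no step between two measured compounds isolates this change alone. What the numbers do show is that both compounds carrying an acyl group on that nitrogen, compound 1 and compound 3, sit far below compound 2, with compound 3 being the closer comparison in its acetamido group. On that basis a large downward step is expected from compound 2 to compound 4, of about a 42-fold lower number from compound 2 to compound 4 (1.63 log units; beyond the scatter), well beyond the scatter. Compound 4 is expected to give 3 nM in this assay, within a range of 0.8 nM to 15 nM.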

Compound 4, half-maximal inhibitory concentration: 4.6 nM
The estimate for compound 4 lay 1.5-fold (0.19 log units) below the measured number; the measured number falls inside the stated range.
By their numbers in this assay, from the lowest: compound 1; then compound 3; then compound 4; then compound 2.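

In this assay, within the data shown here, the change from benzylamino to acetamido gives a 28-fold lower number from compound 2 to compound 4 (1.44 log units; beyond the scatter), the first reading of this position with the aminoalkyl ether chain and the shared core held fixed. Among these compounds, compound 1 and compound 3 differ from compound 2 in more than one place, so only this pair shows that the group on a nitrogen on an aromatic ring alone moves the number far beyond the scatter, with benzyl, which brings a six-membered aromatic ring of carbon only, on the weaker side and acetyl, which brings no ring and a carbonyl, on the stronger side. Nothing shown here ties the step to any one feature of either group.

Which difference between the two groups carries the step stays open: a benzoyl or phenylacetyl group on that nitrogen would keep both the ring and the carbonyl, while a plain methyl or ethyl group would carry neither. Going by these compounds, whether a step of this size would also hold on the core of compound 3 or of compound 1 stays open as well.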